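A Furan in Place of a Thiophene: Compound 4

The source may hold more compounds than are shown below. What is called first, only, known or untested is meant among the compounds shown, and "the series" means these compounds.

Compound 2 `Oc1cccc(-c2cc(-c3ccc(Cl)cc3)nc(-c3ccsc3)c2)c1` gives 11500 nM in a functional assay on T47D cells (Homo sapiens) for cytotoxicity, read by CCK-8 assay and cell counting, with a stated time of 2 days; a lower number here means a stronger inhibitor, a higher number a weaker inhibitor. Among the three measured compounds its number is the second highest: compound 1 `Oc1cccc(-c2cc(-c3ccc(Cl)cc3)nc(-c3cccnc3)c2)c1` gives 18100 nM, and compound 3 `Oc1cccc(-c2cc(-c3ccsc3)nc(-c3cccc(Cl)c3)c2)c1` gives 3540 nM. The step of a 1.6-fold lower number from compound 1 to compound 2 (0.20 log units; within the scatter) is within the scatter, whereas the step of a 3.2-fold lower number from compound 2 to compound 3 (0.51 log units; beyond the scatter) is beyond it. Compound 4 `Oc1cccc(-c2cc(-c3ccc(Cl)cc3)nc(-c3ccco3)c2)c1` differs from compound 2 in one place: furan-2-yl in place of thiophen-3-yl on an aromatic carbon. Going by the values given here, the only measured step that bears on this change is a 1.6-fold lower number from compound 1 to compound 2 (0.20 log units; within the scatter), an exchange of one ring group for another at the same place, which produced no shift beyond the scatter. The step of a 3.2-fold lower number from compound 2 to compound 3 (0.51 log units; beyond the scatter) concerns a different group and offers no guide here. The step of a 1.0-fold higher number from compound 2 to compound 4 (0.02 log units; within the scatter) is therefore expected to stay within the scatter, with no clear direction. Compound 4 is estimated at 12000 nM in this assay, in a range from 5000 nM to 30000 nM.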

Compound 4, half-maximal inhibitory concentration: 10500 nM
The estimate for compound 4 lay 1.1-fold (0.06 log units) above the measured number; low and high end bracket the measured number.
By their numbers in this assay, from the lowest: compound 3; then compounds 4, 2 and 1 (each within the scatter of the next).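

In this assay, replacing the thiophen-3-yl group next to the ring nitrogen with furan-2-yl, which swaps the ring's sulfur for oxygen, leaves the number within the scatter (a 1.1-fold lower number from compound 2 to compound 4 (0.04 log units; within the scatter)). Furan-2-yl in place of pyridin-3-yl also stays within the scatter (a 1.7-fold lower number from compound 1 to compound 4 (0.24 log units; within the scatter)), so pyridin-3-yl, thiophen-3-yl and furan-2-yl, all aromatic rings, are not told apart at this place while the 4-chlorophenyl and 3-hydroxyphenyl groups stay fixed. Nothing available here accounts for this outcome.

On these data alone, all three groups compared at this place are aromatic rings, so it remains open whether an amine, a carboxylic acid or a longer alkyl chain there would shift the number beyond the scatter. As far as these compounds go, it is also open whether furan-2-yl would behave the same way alongside the 3-chlorophenyl group of compound 3.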